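Adding one chain carbon to compound 3

The source may report more compounds than this note shows. Statements on the series, on what has been measured and on what is new or still open speak of the compounds shown alone.

Within the data shown here, in a functional assay on DU-145 cells (Homo sapiens) for antiproliferative activity, read by WST assay, with a stated time of 3 days (on this read-out higher numbers stand for weaker inhibition and lower numbers for stronger inhibition), compound 3 `CCCCN(CCCC)CCCOc1c(-c2cc(OC)c(OC)c(OC)c2)oc2ccccc2c1=O` gives 15700 nM, the only actual number so far. Compound 1 `CCCCCCOc1c(-c2cc(OC)c(OC)c(OC)c2)oc2ccccc2c1=O` stands at a limit of this assay, > 50000 nM. Compound 2 `CCCN(CCC)CCCOc1c(-c2cc(OC)c(OC)c(OC)c2)oc2ccccc2c1=O` stands at the same limit, > 50000 nM. Compound 4 `CCCCN(CCCC)CCCCOc1c(-c2cc(OC)c(OC)c(OC)c2)oc2ccccc2c1=O` differs from compound 3 by (dibutylamino)methyl in place of dibutylamino on a saturated chain carbon, three bonds along the chain from an oxygen on an aromatic ring; the change also reads 2-(dibutylamino)ethyl to 3-(dibutylamino)propyl. The steps bearing on it are an at least 3.1-fold lower number from compound 2 to compound 3 (0.50 log units; beyond the scatter) and an at least 3.1-fold lower number from compound 1 to compound 3 (0.50 log units; beyond the scatter), both bounded by a limit, while a step that the two limits leave unreadable from compound 1 to compound 2 has no readable size. None of them changes the chain length alone. On the strength of an at least 3.1-fold lower number from compound 2 to compound 3 (0.50 log units; beyond the scatter), a small move towards lower numbers in this assay is expected, probably within the scatter. The expected step is a 1.4-fold lower number from compound 3 to compound 4 (0.15 log units; within the scatter). The estimate for compound 4 is 11000 nM, with an expected range of 4000 nM to 35000 nM.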

Compound 4, half-maximal inhibitory concentration: 15300 nM
For compound 4 the middle estimate is 1.4-fold (0.14 log units) below the measured one, within the range that was stated.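

In this assay the chain change from 2-(dibutylamino)ethyl to 3-(dibutylamino)propyl gives a 1.0-fold lower number from compound 3 to compound 4 (0.01 log units; within the scatter), so one extra chain carbon at this position makes no readable difference. Compound 4 also shows an at least 3.2-fold lower number from compound 2 to compound 4 (0.51 log units; beyond the scatter) and an at least 3.2-fold lower number from compound 1 to compound 4 (0.51 log units; beyond the scatter), which places it with compound 3 rather than with the two compounds at the limit. Both sizes are bounded, not exact: the limit of > 50000 nM in this assay, at which 2 of the 4 values shown sit.

Open, on these data alone, is whether a chain longer than 3-(dibutylamino)propyl keeps this level. Also open, as far as these compounds go, is what a ring amine such as piperidine does in place of dibutylamino on either chain.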